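Working notes: heptyl to tert-butoxycarbonyl on compound 2

The source may hold more compounds than are shown below. What is called first, only, known or untested is meant among the compounds shown, and "the series" means these compounds.

Measured compounds:
Compound 1 `CCCCCCCc1c(C)nc2cc(OC)ccc2c1O`: 1020 10^-6 cm/s
Compound 2 `CCCCCCC/C=C/c1c(C)[nH]c2ccccc2c1=O`: 174 10^-6 cm/s

In an ADME assay for permeability, using PAMPA, at pH 4 (on this read-out lower numbers stand for lower permeability and higher numbers for higher permeability), compound 2 stands lowest of the two numbers shown; compound 1 is the nearest, and the gap between them lies beyond the usual scatter. Compound 3 `Cc1[nH]c2ccccc2c(=O)c1/C=C/C(=O)OC(C)(C)C` remains to be measured in this assay. It differs from compound 2 by tert-butoxycarbonyl in place of heptyl on a double-bonded chain carbon bound to a double-bonded chain carbon. Among the measured compounds shown here, no measured pair isolates this change, so the outlook rests on compound 2 alone. A downward step, likely beyond the scatter, is expected, estimated as a 2.2-fold lower number from compound 2 to compound 3 (0.34 log units; beyond the scatter). Compound 3 is expected to give 80 10^-6 cm/s, in the range 30 10^-6 cm/s to 250 10^-6 cm/s.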

Compound 3, apparent permeability: 105 10^-6 cm/s
The estimate for compound 3 lay 1.3-fold (0.12 log units) below the measured number; measured number inside the range.
By their numbers in this assay, from the lowest: compounds 3 and 2 (each within the scatter of the next); then compound 1.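

In this assay, among the compounds shown here, tert-butoxycarbonyl in place of heptyl on a double-bonded chain carbon bound to a double-bonded chain carbon gives a 1.7-fold lower number from compound 2 to compound 3 (0.22 log units; within the scatter) as the only step isolating a change at this position. At this position, then, an all-carbon chain and a group with a carbonyl and hydrogen-bond acceptors give numbers that cannot be told apart on this read-out. No available data bear on the reason for this step. As far as these compounds go, whether an amine, a carboxylic acid or a longer chain at this position would move the number beyond the scatter remains open. So does whether this step would hold on the core of compound 1.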